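Branched ester and amide side chains on a shared core

The source may hold more compounds than are shown below. What is called first, only, known or untested is meant among the compounds shown, and "the series" means these compounds.

Compound 1 `CCCOC(=O)C1=C(C)N(C)C(=O)NC1c1cccs1` and compound 2 `CC1=C(C(=O)OCC(C)C)C(c2cccs2)NC(=O)N1C` share one core, and compound 3 `CCNC(=O)C1=C(C)NC(=O)NC1c1ccoc1` sits on a different core; the difference between the two cores is not broken down here. In an assay on membranes from HeLa cells for displacement of a labelled ligand from adenosine receptor A3 (Homo sapiens), read by scintillation counting, with a stated time of 180 min, tested at 1 uM (a higher number here means more inhibition at the concentration tested (going by the name of the read-out), a lower number less inhibition), compound 1 gives 4% and compound 2 gives 5%, a step of a number 1 percentage points higher from compound 1 to compound 2 (within the scatter) brought by methyl in place of hydrogen on a saturated chain carbon bound to two saturated chain carbons. In this assay compound 3 gives 1%. Compound 4 `CC1=C(C(=O)NC(C)C)C(c2ccoc2)NC(=O)N1`, not yet measured, differs from compound 3 by methyl in place of hydrogen on a saturated chain carbon bound to an amide-type nitrogen and a saturated chain carbon. Going by the values given here, this is the same kind of change as the one from compound 1 to compound 2, though the carbon carrying the new methyl is bound to an amide-type nitrogen and a saturated chain carbon rather than to two saturated chain carbons. Because that earlier step was a number 1 percentage points higher from compound 1 to compound 2 (within the scatter), compound 4 is expected to move by about a number 1 percentage points higher from compound 3 to compound 4 (within the scatter) in this assay. Compound 4 is therefore estimated at 2%, with a likely range from -6% to 10%.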

Compound 4, a percentage reported as inhibition, at one concentration (the size of the read-out at that concentration, not a potency): 3%
The estimate for compound 4 lay 1 percentage points below the measured number; measured number inside the range.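

In this assay, the step for methyl in place of hydrogen on the amide side chain is a number 2 percentage points higher from compound 3 to compound 4 (within the scatter). Set beside the earlier step on the ester side chain, the change reads alike on the two cores: the same change on two cores in this assay, a number 1 percentage points higher (within the scatter) from compound 1 to compound 2 and a number 2 percentage points higher (within the scatter) from compound 3 to compound 4, 1 percentage points apart, within the scatter of two such steps

With both steps this small, the match shows only that neither can be told apart from the scatter; it does not show that the methyl has a real effect that carries from one core to the other. The compounds shown leave open what a longer chain such as butyl, or a carboxylic acid, would give in this assay on either core. They also leave open how this methyl change reads on a compound with a much higher number.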